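The compounds below may be only part of what the source reports. "The series", "measured", "known", "first", "only" and "open" are said of these compounds alone.

Among the compounds with values here, compound 2 `Cc1cc(C)c(CN2CCc3c(Cl)cc(-c4cn[nH]c4C)c(Cl)c3C2=O)c(=O)[nH]1` is one of three compounds measured in an assay on Sf9 cells for inhibition of histone-lysine N-methyltransferase EZH2 (Homo sapiens), read by scintillation counting, with a stated time of 60 min, in the presence of a further agent that is not named here (a lower number here means a stronger inhibitor, a higher number a weaker inhibitor), where compound 2 gives 24 nM. Compound 1 `Cc1cc(C)c(CN2CCc3c(C)cc(O[C@@H]4CCOC4)c(Cl)c3C2=O)c(=O)[nH]1` gives 18 nM in this assay, a number within the scatter of that of compound 2, so the two are not separated. Compound 3 `COc1cccc(C(=O)NCc2c(C)cc(C)[nH]c2=O)c1` reaches only a limit in this assay, > 150000 nM, and not a number. Compound 4 `Cc1cc(C)c(CN2CCc3c(Cl)cc(-c4cn[nH]c4)c(Cl)c3C2=O)c(=O)[nH]1` has not yet been measured; it differs from compound 2 by hydrogen in place of methyl on an aromatic carbon. Within the data shown here, no measured pair shows the effect of such a change, so the step can only be expected: a small loss, at most just beyond the scatter. Compound 4 is therefore expected to give 45 nM in this assay, between 15 nM and 150 nM. That estimate means an expected step of a 1.9-fold higher number from compound 2 to compound 4 (0.27 log units; within the scatter) toward a weaker inhibitor.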

Compound 4, half-maximal inhibitory concentration: 51 nM
Compound 4: middle estimate off by 1.1-fold (0.05 log units), on the low side; the range from low to high includes it.
By their numbers in this assay, from the lowest: compounds 1 and 2 (each within the scatter of the next); then compound 4. At a limit, above all of these: compound 3.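

Within the data shown here, with the pair of compound 2 and compound 4, this assay gives the first reading at this position: going from 5-methyl-1H-pyrazol-4-yl to 1H-pyrazol-4-yl produces a 2.1-fold higher number from compound 2 to compound 4 (0.33 log units; beyond the scatter). The methyl therefore contributes modestly, and inhibition in the nanomolar range survives its loss. Nothing measured here bears on the cause of this step. The compounds shown leave open how an ethyl group, a chlorine or an amine on this same aromatic carbon would read. They also leave open whether a ring nitrogen carrying a methyl group would change the number.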